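The compounds below may be only part of what the source reports. "The series", "measured", "known", "first", "only" and "open" are said of these compounds alone.

The account rests on two measured acids. Compound 1 `CN(C)S(=O)(=O)c1ccc(F)c(C#Cc2cc(Cl)ccc2OCC(=O)O)c1` carries a dimethylsulfamoyl group, and in a functional assay on cells for antagonist activity at prostaglandin D2 receptor 2 (Homo sapiens), read by flow cytometry, with a stated time of 10 min (a lower number here means a stronger inhibitor, a higher number a weaker inhibitor), compound 1 gives 23 nM. Compound 2 `Cc1ccc(S(=O)(=O)CC(C)C)cc1C#Cc1cc(Cl)ccc1OCC(=O)O` carries an isobutylsulfonyl group and a methyl group instead; in this assay compound 2 gives 120 nM, the higher of the two numbers, and the gap to compound 1 lies beyond the scatter. Since these two compounds differ in more than one place, their values are only set side by side. Compound 3 `Cc1ccc(S(=O)(=O)N(C)C)cc1C#Cc1cc(Cl)ccc1OCC(=O)O` keeps the core of compound 2 and alters one thing: dimethylamino in place of isobutyl on a sulfonyl sulfur. Among the measured compounds shown here, no measured pair shows this step on its own. Compound 1 carries the same dimethylsulfamoyl group, and in this assay compound 1 gives 23 nM, which supports a fall. The step from compound 2 to compound 3 is expected to be a 2.4-fold lower number from compound 2 to compound 3 (0.38 log units; beyond the scatter). Compound 3 is therefore estimated at 50 nM, with a range from 15 nM to 150 nM.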

Compound 3, half-maximal inhibitory concentration: 77 nM
For compound 3 the middle estimate is 1.5-fold (0.19 log units) below the measured one, and the stated range covers the measured number.
By their numbers in this assay, from the lowest: compound 1; then compounds 3 and 2 (each within the scatter of the next).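

In this assay, dimethylamino in place of isobutyl on a sulfonyl sulfur gives a 1.6-fold lower number from compound 2 to compound 3 (0.19 log units; within the scatter), so on this core the assay does not separate the two groups. Methyl in place of fluoro on an aromatic carbon, with the dimethylsulfamoyl group held fixed, gives a 3.3-fold higher number from compound 1 to compound 3 (0.52 log units; beyond the scatter), and this is the one single-place step shown that lies beyond the scatter. No measurement at hand bears on the reason for either step.

Going by these compounds, it remains open whether isobutyl on the sulfonyl sulfur would respond to fluoro in place of methyl as the dimethylamino compounds do. Also open, on these data alone, is how a chloro or methoxy group on that aromatic carbon, or a piperidine on the sulfonyl sulfur, would read in this assay.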